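The source may report more compounds than this note shows. Statements on the series, on what has been measured and on what is new or still open speak of the compounds shown alone.

In a functional assay on B16 cells (Mus musculus) for antiproliferative activity, read by MTT assay, with a stated time of 24 h (a higher number here means a weaker inhibitor, a lower number a stronger inhibitor), three compounds sharing one core have been measured. Compound 1 `C=CCOc1ccc2c(=O)c(-c3cc(OC)c(OC)cc3OC)coc2c1` gives 5100 nM, compound 2 `COc1cc(OC)c(-c2coc3cc(OCc4ccccc4)ccc3c2=O)cc1OC` gives 2330 nM, and compound 3 `COc1cc(OC)c(-c2coc3cc(OCc4ccc(F)cc4)ccc3c2=O)cc1OC` gives 1120 nM, the lowest of the three numbers. The next compound, compound 4 `COc1cc(OC)c(-c2coc3cc(OCc4ccccc4C)ccc3c2=O)cc1OC`, departs from compound 3 in a single group: 2-methylphenyl in place of 4-fluorophenyl on a saturated chain carbon bound to an oxygen on an aromatic ring.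

Among the compounds with values here, three measured steps bear on this change. Phenyl in place of vinyl gave a 2.2-fold lower number from compound 1 to compound 2 (0.34 log units; beyond the scatter), and 4-fluorophenyl in place of vinyl gave a 4.6-fold lower number from compound 1 to compound 3 (0.66 log units; beyond the scatter). Fluoro in place of hydrogen on an aromatic carbon gave a 2.1-fold lower number from compound 2 to compound 3 (0.32 log units; beyond the scatter), and this is the step that compound 4 gives up. Within the data shown here, no measured compound carries a methyl on this ring, so what the methyl does is unknown. The best guide is compound 2 at 2330 nM, which also lacks the fluoro.

A modest change is therefore expected, estimated as a 1.8-fold higher number from compound 3 to compound 4 (0.25 log units; within the scatter). For compound 4 the estimated value in this assay is 2000 nM, with an expected range of 800 nM to 5000 nM.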

Compound 4, half-maximal inhibitory concentration: 2150 nM
Beside the measured number, compound 4's estimate is 1.1-fold (0.03 log units) below it, and the stated range covers the measured number.
By their numbers in this assay, from the lowest: compounds 3, 4 and 2 (each within the scatter of the next, the first and the last beyond it); then compound 1.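

In this assay, 2-methylphenyl in place of 4-fluorophenyl on the saturated chain carbon gives a 1.9-fold higher number from compound 3 to compound 4 (0.28 log units; within the scatter) and so does not separate the two compounds. Within the data shown here, this is the first methyl seen on this ring, and methyl in place of hydrogen gives a 1.1-fold lower number from compound 2 to compound 4 (0.03 log units; within the scatter) and so leaves no reading for the methyl in this assay, unlike the fluoro step, which was beyond the scatter. The vinyl comparison now has a third ring-bearing member, with 2-methylphenyl in place of vinyl giving a 2.4-fold lower number from compound 1 to compound 4 (0.38 log units; beyond the scatter) and compound 1 still standing apart from compounds 2, 3 and 4.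

Still open, going by these compounds, is whether a methyl elsewhere on this ring, an amine or a carboxylic acid on it, or a longer chain in its place would shift these numbers. Nothing given here accounts for any of these steps.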